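Swapping an Aromatic Ring for a Phenethyl Chain

The source may report more compounds than this note shows. Statements on the series, on what has been measured and on what is new or still open speak of the compounds shown alone.

Of the compounds shown here, three that share a common core have been tested in an assay for inhibition of 3-hydroxy-3-methylglutaryl-coenzyme A reductase (Rattus norvegicus); a lower number here means a stronger inhibitor, a higher number a weaker inhibitor. Compound 1 `Cc1cc(-c2cc(Cl)cc(C)c2/C=C/[C@@H]2C[C@@H](O)CC(=O)O2)ccc1F` gives 6 nM in this assay. Compound 3 `Cc1cc(C)c(/C=C/[C@@H]2C[C@@H](O)CC(=O)O2)c(-c2ccc(F)cc2)c1` gives 13 nM in this assay. Compound 2 `Cc1cc(F)ccc1-c1cc(Cl)cc(Cl)c1/C=C/[C@@H]1C[C@@H](O)CC(=O)O1` gives 36 nM in this assay, the highest of the three numbers; its gap to compound 3 lies beyond the usual scatter, and its gap to compound 1 is wider still. Among the compounds with a number in hand, compound 2 is thus the weakest inhibitor.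

Compound 4 `O=C1C[C@H](O)C[C@@H](/C=C/c2c(Cl)cc(Cl)cc2CCc2ccccc2)O1` has not yet been tested in this assay. It differs from compound 2 in one place: phenethyl in place of 4-fluoro-2-methylphenyl on an aromatic carbon. Among the compounds with values here, no pair of measured compounds shows a change of this kind, so the step cannot be read from neighbours. All three measured compounds carry a six-membered aromatic ring of carbon only directly on that aromatic carbon, and none carries a chain there. Without a guide, the step is expected to be modest, with a slight lean towards a higher number, meaning a weaker inhibitor, as the estimated step of a 1.7-fold higher number from compound 2 to compound 4 (0.22 log units; within the scatter) expresses. Compound 4 is expected to give about 60 nM in this assay, within a range from 15 nM to 250 nM.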

Compound 4, half-maximal inhibitory concentration: 430 nM
The estimate for compound 4 lay 7.2-fold (0.86 log units) below the measured number; measured number outside the range, above it.
By their numbers in this assay, from the lowest: compound 1; then compound 3; then compound 2; then compound 4.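

In this assay, putting phenethyl in place of 4-fluoro-2-methylphenyl on this aromatic carbon gives a 12-fold higher number from compound 2 to compound 4 (1.08 log units; beyond the scatter) and makes compound 4 a clearly weaker inhibitor, so this position is far from indifferent to the group it carries. The two groups look alike on simple counts, with the same number of heavy atoms, one six-membered aromatic ring of carbon only, and no hydrogen-bond donors or acceptors, yet those shared counts do not keep the number steady; phenethyl differs in holding its ring on a chain and in carrying no fluorine or methyl. Nothing measured here accounts for the loss.

This single step changes the chain and the ring substituents together, so the compounds shown cannot say which of the two matters more. A plain phenyl ring would address the substituents, while a benzyl group or a longer chain such as 3-phenylpropyl would test how the length of the chain affects the number, and a chain ending in an amine would show whether this position accepts anything other than carbon rings.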